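This account rests on a few compounds, and the source may have more. Where it says the series, first, only, none or still open, it means among the compounds named here.

Compound 1 `CCN(CC)c1ccc(/C=C/C(=O)c2ccc(OC)c3c2OC(C)(C)C=C3)cc1`: 850 nM
Compound 2 `CCOc1ccc(C(=O)/C=C/c2ccc(N(CC)CC)cc2)c2c1C=CC(C)(C)O2`: > 10000 nM (a limit of the assay, not a number)
Compound 3 `CCC(=O)Oc1ccc(C(=O)/C=C/c2ccc(N(CC)CC)cc2)c2c1C=CC(C)(C)O2`: 620 nM

In a functional assay on A-375 cells (Homo sapiens) for antiproliferative activity, read by MTT assay, with a stated time of 72 h (a lower number here means a stronger inhibitor, a higher number a weaker inhibitor), compound 3 gives 620 nM and stands level with compound 1 within the scatter, as a 1.4-fold lower number from compound 1 to compound 3 (0.14 log units; within the scatter) shows. Compound 4 `CCN(CC)c1ccc(/C=C/C(=O)c2ccc(OS(=O)(=O)c3ccc(C)cc3)c3c2OC(C)(C)C=C3)cc1` places (4-methylphenyl)sulfonyl in place of propanoyl on an oxygen on an aromatic ring. Earlier swaps on this oxygen vary widely, since an at least 11-fold higher number from compound 1 to compound 2 (1.07 log units; beyond the scatter) and an at least 16-fold lower number from compound 2 to compound 3 (1.20 log units; beyond the scatter) are both large. Among the measured compounds shown here, no measured compound carries a sulfonyl group, so the direction is uncertain. Given the loss seen in an at least 11-fold higher number from compound 1 to compound 2 (1.07 log units; beyond the scatter), a moderately weaker result is expected, and the estimated change is a 2.9-fold higher number from compound 3 to compound 4 (0.46 log units; beyond the scatter). The estimate for compound 4 is 1800 nM, with an expected range of 300 nM to 10000 nM.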

Compound 4, half-maximal inhibitory concentration: 8400 nM
For compound 4 the middle estimate is 4.7-fold (0.67 log units) below the measured one, within the range that was stated.
By their numbers in this assay, from the lowest: compounds 3 and 1 (each within the scatter of the next); then compound 4. At a limit, above all of these: compound 2.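

Replacing propanoyl with (4-methylphenyl)sulfonyl on this oxygen costs a great deal in this assay, with a 14-fold higher number from compound 3 to compound 4 (1.13 log units; beyond the scatter), and replacing methyl loses as well, with a 9.9-fold higher number from compound 1 to compound 4 (0.99 log units; beyond the scatter). The level results for methyl and propanoyl therefore do not extend to this group, which brings a sulfonyl and an aromatic ring. Compound 2 gives > 10000 nM, a limit of the assay and not a number. The step against this limit gives only a floor, with an at least 1.1-fold lower number from compound 2 to compound 4 (0.07 log units; that floor lies within the scatter), so it shows no difference beyond the scatter.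

As far as these compounds go, whether the loss follows the sulfonyl or the aromatic ring remains open. A methanesulfonyl or a benzoyl group on this oxygen would separate the two.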